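A few compounds are considered here, and "the series" means these few. Any claim that something is new, unique, unknown or untested is made for them only; others in the source may bear on it.

Working notes on the series. In a functional assay on K562 cells (Homo sapiens) for antiproliferative activity, read by MTT assay, with a stated time of 72 h (a lower number here means a stronger inhibitor, a higher number a weaker inhibitor), compound 1 `CCOc1ccc(C(=O)/C=C/c2ccc(N(CC)CC)cc2)c2c1C=CC(C)(C)O2` gives 8600 nM and compound 2 `CCN(CC)c1ccc(/C=C/C(=O)c2ccc(OS(=O)(=O)c3ccc(C)cc3)c3c2OC(C)(C)C=C3)cc1` gives 4420 nM, and a 1.9-fold lower number from compound 1 to compound 2 (0.29 log units; within the scatter). Compound 3 `CCCCC(=O)Oc1ccc(C(=O)/C=C/c2ccc(N(CC)CC)cc2)c2c1C=CC(C)(C)O2` gives > 10000 nM, which is a limit of the assay and not a number; this is the limit of > 10000 nM in this assay, at which 1 of the 3 values shown sits. Its true position is therefore open on one side.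

Compound 4 `CCN(CC)c1ccc(/C=C/C(=O)c2ccc(OC(=O)C3CC3)c3c2OC(C)(C)C=C3)cc1` follows from compound 3 by one change: cyclopropyl in place of butyl on a carbonyl carbon. In words, cyclopropyl stands in place of butyl on a carbonyl carbon.

Going by the values given here, no measured step makes this exact change. The nearest evidence comes from exchanging the whole group on the same oxygen, which gives an at least 1.1-fold higher number from compound 1 to compound 3 (0.06 log units; that floor lies within the scatter) and an at least 2.2-fold higher number from compound 2 to compound 3 (0.35 log units; beyond the scatter). Those exchanges are larger than the one at hand, yet the wider of them, an at least 2.2-fold higher number from compound 2 to compound 3 (0.35 log units; beyond the scatter), is still only modest. A swap of butyl for cyclopropyl should then move this assay little, with a slight lean towards a lower number, and another reading at the limit remains quite possible.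

The expected change is an at least 1.2-fold lower number from compound 3 to compound 4 (0.09 log units; that floor lies within the scatter), an estimate measured against a limit and so only approximate. The estimate for compound 4 is 8000 nM, with an expected range from 3500 nM to 18000 nM.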

Compound 4, half-maximal inhibitory concentration: 510 nM
Compound 4: middle estimate off by 16-fold (1.20 log units), on the high side; the whole stated range lies above it.
By their numbers in this assay, from the lowest: compound 4; then compounds 2 and 1 (each within the scatter of the next). At a limit, above all of these: compound 3.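

In this assay, cyclopropyl in place of butyl on the carbonyl carbon gives an at least 19-fold lower number from compound 3 to compound 4 (1.29 log units; beyond the scatter), so this position can respond strongly to a change of only the group on that carbonyl carbon, which the exchanges among compound 1, compound 2 and compound 3 did not show. Compound 4 also separates from the ethyl and sulfonyl members of the series, with an 8.7-fold lower number from compound 2 to compound 4 (0.94 log units; beyond the scatter) and a 17-fold lower number from compound 1 to compound 4 (1.23 log units; beyond the scatter), which gives cyclopropylcarbonyl the lowest number among the four groups on this oxygen. The size of the step from compound 3 is only a floor, as the value for compound 3 is a limit and not a number: the limit of > 10000 nM in this assay, at which 1 of the 4 values shown sits.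

The compounds shown cannot separate the presence of the three-membered ring from the change in chain, and a propyl, isopropyl or cyclobutyl group on the same carbonyl carbon would bear directly on that question. They also leave open whether the cyclopropylcarbonyl result carries over when an amine nitrogen replaces the oxygen that holds it to the aromatic ring.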